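Benzyl ester variations on a shared tetrazole core

The source may report more compounds than this note shows. Statements on the series, on what has been measured and on what is new or still open speak of the compounds shown alone.

Compound 1: `CCCc1nc(CC)c(C(=O)OCc2ccc(C(=O)c3ccccc3)cc2)n1Cc1ccc(-c2ccccc2-c2nn[nH]n2)cc1`, 2000 nM in an assay on isolated protein for binding affinity to Type-2 angiotensin II receptor (Homo sapiens); a higher number here means a weaker inhibitor, a lower number a stronger inhibitor
Compound 2: `CCCc1nc(CC)c(C(=O)OCc2ccccc2-c2ccccc2)n1Cc1ccc(-c2ccccc2-c2nn[nH]n2)cc1`, 2000 nM in this assay

In this assay compound 2 stands level with compound 1, the two values being within the scatter of each other. Compound 3, `CCCc1nc(CC)c(C(=O)OCc2ccc(-c3ccccc3)cc2)n1Cc1ccc(-c2ccccc2-c2nn[nH]n2)cc1`, carries 4-phenylphenyl in place of 2-phenylphenyl on a saturated chain carbon bound to an oxygen next to a carbonyl group. Compound 1 already shows that a group placed on the far side of this benzyl ring can give the same reading as compound 2, so no step beyond the scatter is expected from compound 2 to compound 3, that is no change at the digits printed from compound 2 to compound 3 (within the scatter). Compound 3 is therefore estimated at 2000 nM, within a range from 700 nM to 6000 nM.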

Compound 3, half-maximal inhibitory concentration: 3000 nM
Compound 3: the middle estimate sits 1.5-fold (0.18 log units) below what was measured, within the range that was stated.
By their numbers in this assay, from the lowest: compounds 1, 2 and 3 (each within the scatter of the next).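

Within this assay the swap of 2-phenylphenyl for 4-phenylphenyl gives a 1.5-fold higher number from compound 2 to compound 3 (0.18 log units; within the scatter) and so shows that moving the second ring around the benzyl ring leaves the reading within the scatter. Phenyl in place of benzoyl on an aromatic carbon gives a 1.5-fold higher number from compound 1 to compound 3 (0.18 log units; within the scatter) and so adds a second pair that cannot be told apart. Nothing available explains either result.

All three compounds carry two or more aromatic rings in this ester. As far as these compounds go, whether an amine or a carboxylic acid on the benzyl ring, or a plain ethyl ester, would move the number beyond the scatter remains open.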